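A few compounds are considered here, and "the series" means these few. Any claim that something is new, unique, unknown or untested is made for them only; others in the source may bear on it.

Compound 1 `COC(=O)C1=C(CN2CCOCC2=O)NC(c2nccs2)=NC1(C)c1ccc(F)cc1` and compound 2 `COC(=O)C1=C(CN2CCNC(=O)C2)NC(c2nccs2)=NC1(C)c1ccc(F)cc1` share one core and differ only in the ring attached to a saturated chain carbon bound to a double-bonded ring carbon. In an ADME assay on microsomes from liver (Mus musculus) for metabolic stability, read by LC-MS, using NADPH, with stated times of 10 min and 30 min, tested at 1 uM (on this read-out lower numbers stand for slow clearance and higher numbers for fast clearance), compound 1 gives 80 mL/min/kg, and compound 2 gives 81 mL/min/kg. The step of a 1.0-fold higher number from compound 1 to compound 2 (0.01 log units; within the scatter) shows that this swap of rings left the clearance essentially unchanged. Among the two measured compounds, compound 2 has the highest number, but the gap to compound 1 is within the scatter, so neither can be called faster or slower.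

Compound 3 `COC(=O)C1=C(CN2CCC(C(F)(F)F)C2)NC(c2nccs2)=NC1(C)c1ccc(F)cc1` brings a different change: 3-(trifluoromethyl)pyrrolidin-1-yl in place of 3-oxopiperazin-1-yl on a saturated chain carbon bound to a double-bonded ring carbon. For the measured compounds named here, only the step from compound 1 to compound 2 bears on it, and that step was within the scatter. The expectation is therefore a step of a 1.0-fold higher number from compound 2 to compound 3 (0.02 log units; within the scatter) in this assay, with no clear direction beyond the scatter. Compound 3 is estimated at 85 mL/min/kg, with a range from 50 mL/min/kg to 150 mL/min/kg.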

Compound 3, clearance: 88 mL/min/kg
For compound 3 the middle estimate is 1.0-fold (0.02 log units) below the measured one; low and high end bracket the measured number.
By their numbers in this assay, from the lowest: compounds 1, 2 and 3 (each within the scatter of the next).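

Swapping 3-oxopiperazin-1-yl for 3-(trifluoromethyl)pyrrolidin-1-yl is a much larger change than the swap between compound 1 and compound 2: the ring shrinks to five members, the hydrogen-bond donor is lost and three fluorine atoms enter. Even so, this assay gives a 1.1-fold higher number from compound 2 to compound 3 (0.04 log units; within the scatter) and also a 1.1-fold higher number from compound 1 to compound 3 (0.04 log units; within the scatter), so the three rings on a saturated chain carbon bound to a double-bonded ring carbon cannot be told apart by clearance, even with this wider variety of ring. No supporting data are available that bear on this result.

On these data alone, whether the same holds for an open-chain amine such as dimethylamino or for a carboxylic acid at this place remains open. So does the question of whether changes elsewhere on the shared core would shift the clearance.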